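Moving the ring nitrogen around on a pyridyl substituent

A few compounds are considered here, and "the series" means these few. Any claim that something is new, unique, unknown or untested is made for them only; others in the source may bear on it.

Measured compounds:
- Compound 1, `COc1ccc(OC)c(Sc2ccc3nnc(-c4ccccc4)n3n2)c1`: 173 nM
- Compound 2, `COc1ccc(OC)c(Sc2ccc3nnc(-c4ccccn4)n3n2)c1`: 496 nM
- Compound 3, `COc1ccc(OC)c(Sc2ccc3nnc(-c4cccnc4)n3n2)c1`: 242 nM

All three compounds were tested in an assay on isolated protein for inhibition of Leucine-rich repeat serine/threonine-protein kinase 2 (Homo sapiens), in the presence of a further agent that is not named here; a higher number here means a weaker inhibitor, a lower number a stronger inhibitor. They share one core and differ only in the aromatic ring attached to it: compound 1 carries a phenyl, compound 2 a pyridin-2-yl, and compound 3 a pyridin-3-yl. Among the three numbers, compound 3 stands second highest; it sits close to compound 1, since a 1.4-fold higher number from compound 1 to compound 3 (0.15 log units; within the scatter), while compound 2 is further away, with a 2.0-fold lower number from compound 2 to compound 3 (0.31 log units; beyond the scatter). The exchange of phenyl for pyridin-2-yl gave the largest shift seen, a 2.9-fold higher number from compound 1 to compound 2 (0.46 log units; beyond the scatter).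

Compound 4, `COc1ccc(OC)c(Sc2ccc3nnc(-c4ccncc4)n3n2)c1`, is not yet measured. It differs from compound 3 in one place: pyridin-4-yl in place of pyridin-3-yl on an aromatic carbon. The two measured steps that move the ring nitrogen were modest, and the closest comparison, pyridin-3-yl beside phenyl, stayed within the scatter. The step is therefore expected to be small in this assay, and compound 4 is estimated to give 280 nM, within a range of 130 nM to 650 nM, which means an expected step of a 1.2-fold higher number from compound 3 to compound 4 (0.06 log units; within the scatter).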

Compound 4, half-maximal inhibitory concentration: 349 nM
The estimate for compound 4 lay 1.2-fold (0.10 log units) below the measured number, within the range that was stated.
By their numbers in this assay, from the lowest: compounds 1, 3, 4 and 2 (each within the scatter of the next, the first and the last beyond it).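

With pyridin-4-yl in place, all three pyridyl isomers can be compared, and compound 4 cannot be separated from any of the other compounds: there is a 1.4-fold higher number from compound 3 to compound 4 (0.16 log units; within the scatter), a 1.4-fold lower number from compound 2 to compound 4 (0.15 log units; within the scatter) and a 2.0-fold higher number from compound 1 to compound 4 (0.30 log units; within the scatter). This last step is close to the limit of the scatter but is still within it, so among the three pyridyl compounds only compound 2 differs from compound 1 by more than the scatter. A ring nitrogen in this group therefore does not always set it apart from phenyl, and compound 2 is the one exception.

Nothing measured here speaks to what lies behind these small differences. From the compounds shown here alone, it also remains open whether an amine, a carboxylic acid or a longer alkyl chain at this position would move the number further than any pyridyl ring has.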